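The compounds below may be only part of what the source reports. "The series", "measured", "known", "first", "only" and "open" are said of these compounds alone.

Working notes on the series.

In an assay on membranes from brain for displacement of a labelled ligand from Sigma non-opioid intracellular receptor 1 (Cavia porcellus) (on this read-out higher numbers stand for weaker inhibition and lower numbers for stronger inhibition), compound 1 `CCC(=O)c1ccc2c(c1)sc(=O)n2CCCN1CCCCC1` gives 2.3 nM and stands at the lowest number of the three measured. Compound 3 `CCCCc1ccc2c(c1)sc(=O)n2CCN1CCCCC1` gives 3.7 nM in this assay, a figure within the scatter of compound 1, so the two cannot be told apart. Within the data shown here, compound 2 `CCC(=O)c1ccc2c(c1)oc(=O)n2CCCN1CCCCC1` gives 8.5 nM in this assay, a number beyond the scatter above compound 1, and is the only measured member that separates from it. No single-point comparison between measured compounds is available, so no measured step sizes can be quoted.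

Compound 4 `CCCc1ccc2c(c1)sc(=O)n2CCCN1CCCCC1` is the next candidate, not yet measured in this assay. It differs from compound 1 in one place: propyl in place of propanoyl on an aromatic carbon. The series already holds an aromatic alkyl chain in compound 3, which in this assay gives 3.7 nM, close to compound 1, so a large loss is not indicated. The expectation for the step from compound 1 to compound 4 in this assay is a 1.7-fold higher number from compound 1 to compound 4 (0.24 log units; within the scatter), most likely none beyond the scatter, with a slight lean toward a higher number.

Compound 4 is estimated to give 4 nM in this assay, with a range of 1.5 nM to 12 nM.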

Compound 4, inhibition constant: 1.2 nM
For compound 4 the middle estimate is 3.3-fold (0.52 log units) above the measured one; measured number outside the range, below it.
By their numbers in this assay, from the lowest: compounds 4, 1 and 3 (each within the scatter of the next, the first and the last beyond it); then compound 2.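

Propyl in place of propanoyl on this aromatic carbon gives a 1.9-fold lower number from compound 1 to compound 4 (0.28 log units; within the scatter) in this assay, so the two compounds cannot be told apart. Among these compounds, this is the first comparison that isolates a single place, and it shows that the carbonyl of propanoyl, with the one hydrogen-bond acceptor counted for that group, is not required at this position for a value in the low nanomolar range; one fewer heavy atom in the group also brings no change beyond the scatter. Nothing at hand accounts for the two groups reading alike, and this single pair gives no explanation for it.

The compounds shown leave open how far this position accepts other groups, such as a longer chain like hexyl, an amine or a carboxylic acid, as only propyl and propanoyl can be compared here on an otherwise identical molecule. They also leave open whether the same exchange of propanoyl for propyl reads the same way on the core of compound 2.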